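The compounds below may be only part of what the source reports. "The series", "measured", "known", "first", "only" and "open" are said of these compounds alone.

The series rests on a shared bicyclic core carrying a carboxylic-acid-bearing side chain, as in compound 1 `CSCSCC1C2CCC(O2)C1C/C=C\CCCC(=O)O`. In a functional assay on a cell-free system (plasma) for inhibition of thromboxane A2 receptor (Homo sapiens) (on this read-out lower numbers stand for stronger inhibition and higher numbers for weaker inhibition), compound 1 gives 700 nM. Compound 2 `CCC/C=C/CSCC1C2CCC(O2)C1C/C=C\CCCC(=O)O`, in which pent-1-en-1-yl replaces methylsulfanyl on a saturated chain carbon bound to a sulfur, gives in this assay 1300 nM. Among the compounds with values here, the step of a 1.9-fold higher number from compound 1 to compound 2 (0.27 log units; within the scatter) is the only one measured so far, so compound 2 stands within the scatter of compound 1, the only other number available.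

Compound 3 `CCC/C=C\CSCC1C2CCC(O2)C1C/C=C\CCCC(=O)O` differs from compound 2 in this way: the two compounds have the same atoms and bonds; at least one stereo element is drawn with a configuration in one of them and without one in the other: 1 of 6 stereo elements differ; a double bond is drawn E in compound 2 and Z in compound 3. Within the data shown here, no measured step concerns a change of double-bond geometry; the one known step, a 1.9-fold higher number from compound 1 to compound 2 (0.27 log units; within the scatter), replaces the whole group rather than turning one of its bonds, and that step itself was within the scatter. There is therefore no basis in the numbers shown for expecting a shift in this assay beyond the scatter, in either direction.

Compound 3 is accordingly expected to give in this assay about 1300 nM, with a range from 450 nM to 3800 nM. The corresponding expected step is no change at the digits printed from compound 2 to compound 3 (within the scatter).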

Compound 3, half-maximal inhibitory concentration: 5700 nM
Compound 3: middle estimate off by 4.4-fold (0.64 log units), on the low side; the measured number lies above the stated range.
By their numbers in this assay, from the lowest: compounds 1 and 2 (each within the scatter of the next); then compound 3.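

The geometry of the double bond in the pent-1-en-1-yl group matters on this read-out. In this assay, within the data shown here, turning it from E to Z with no other change gives a 4.4-fold higher number from compound 2 to compound 3 (0.64 log units; beyond the scatter), so a change that leaves atoms and bonds untouched moves the number beyond the scatter, which the one earlier step did not do. The exchange of methylsulfanyl for pent-1-en-1-yl also depends on this geometry: with the E form it gave a 1.9-fold higher number from compound 1 to compound 2 (0.27 log units; within the scatter), whereas with the Z form it gives an 8.1-fold higher number from compound 1 to compound 3 (0.91 log units; beyond the scatter), so the group is tolerated within the scatter only in the E form, and how firmly the shift can be tied to geometry alone is limited by one point: the fact that one of compounds 2 and 3 is drawn with a defined configuration and the other without, at the place where they differ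

The compounds shown leave open whether the weaker inhibition belongs to the Z double bond itself or would also appear with other groups in this place. From the compounds shown here alone, how a saturated pentyl chain, a longer chain or a phenyl ring on the sulfur would compare with compound 1 and compound 2 in this assay remains unknown here.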